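The source may hold more compounds than are shown below. What is called first, only, known or untested is meant among the compounds shown, and "the series" means these compounds.

Working notes on the series in a toxicity assay on HepG2 2.2.15 cells (Homo sapiens) for cytotoxicity, read by CellTiter-Glo; a lower number here means that less compound is tolerated, a higher number that more compound is tolerated. Compound 1 `O=C1OC(c2ccccc2)CN1c1cnn2c1CN(C(=O)Nc1cc(F)c(F)c(F)c1)C(C1CC1)C2` gives 7410 nM, compound 2 `O=C1CC(c2ncc(F)cn2)CN1c1cnn2c1CN(C(=O)Nc1cc(F)c(F)c(F)c1)C(C1CC1)C2` gives 115000 nM, and compound 3 `O=C1CC(c2ccccn2)CN1c1cnn2c1CN(C(=O)Nc1cc(F)c(F)c(F)c1)C(C1CC1)C2` gives 96200 nM. Compound 3 therefore sits level with compound 2, within the scatter, and well clear of compound 1.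

The next compound is compound 4 `O=C1CC(c2ccccc2)CN1c1cnn2c1CN(C(=O)Nc1cc(F)c(F)c(F)c1)C(C1CC1)C2`, with phenyl in place of pyridin-2-yl on a saturated ring carbon.

For the measured compounds named here, two measured steps bear on this change. The step of a 1.2-fold lower number from compound 2 to compound 3 (0.08 log units; within the scatter) exchanges only the aromatic group on that saturated ring carbon and stays within the scatter. The step of a 13-fold higher number from compound 1 to compound 3 (1.11 log units; beyond the scatter) is large, but it replaces the whole 2-oxo-5-phenyl-1,3-oxazolidin-3-yl group with 2-oxo-4-(pyridin-2-yl)pyrrolidin-1-yl, so the data cannot separate the ring change from the change of aromatic group. Compound 1, at 7410 nM, also carries a phenyl group, and this points weakly downward. A moderate step to a lower number is therefore expected in this assay, smaller than the large step above. The expected change is a 2.1-fold lower number from compound 3 to compound 4 (0.33 log units; beyond the scatter). For compound 4 the estimate is 45000 nM, with an expected range of 14000 nM to 110000 nM.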

Compound 4, half-maximal cytotoxic concentration: 12800 nM
Estimate against measurement, compound 4: 3.5-fold (0.55 log units) above, outside the stated range (below it).
By their numbers in this assay, from the lowest: compounds 1 and 4 (each within the scatter of the next); then compounds 3 and 2 (each within the scatter of the next).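

In this assay the aromatic group on this saturated ring carbon proves to be decisive: phenyl in place of pyridin-2-yl gives a 7.5-fold lower number from compound 3 to compound 4 (0.88 log units; beyond the scatter), and phenyl in place of 5-fluoropyrimidin-2-yl gives a 9.0-fold lower number from compound 2 to compound 4 (0.95 log units; beyond the scatter), whereas the exchange of those two nitrogen-containing rings had stayed within the scatter. With phenyl on both sides, 2-oxo-4-phenylpyrrolidin-1-yl in place of 2-oxo-5-phenyl-1,3-oxazolidin-3-yl gives a 1.7-fold higher number from compound 1 to compound 4 (0.24 log units; within the scatter), so the two five-membered rings cannot be told apart here, and the large earlier step from the oxazolidinone of compound 1 to the pyrrolidinone of compound 3 now tracks the change of aromatic group rather than the ring change. Nothing available gives a reason for the phenyl result.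

The compounds shown leave open how pyridin-3-yl, cyclohexyl, or an amine or carboxylic acid on that saturated ring carbon would read in this assay. Also open, going by these compounds, is whether 2-oxo-5-(pyridin-2-yl)-1,3-oxazolidin-3-yl would give the same step from phenyl on the other ring.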